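The source may report more compounds than this note shows. Statements on the series, on what has been measured and on what is new or still open speak of the compounds shown alone.

Measured in a functional assay on cells (Homo sapiens) for antiproliferative activity, read by WST assay, with a stated time of 3 days; a higher number here means a weaker inhibitor, a lower number a stronger inhibitor:
- compound 1 `[N-]=[N+]=Nc1cc(=O)[nH]c(=O)n1[C@@H]1O[C@H](CO)[C@@H](O)[C@H]1O`: > 50000 nM
- compound 2 `CNc1cc(=O)[nH]c(=O)n1[C@@H]1O[C@H](CO)[C@@H](O)[C@H]1O`: > 50000 nM
- compound 3 `O=c1cc(NO)n([C@@H]2O[C@H](CO)[C@@H](O)[C@H]2O)c(=O)[nH]1`: > 50000 nM

Each entry is a limit, not a number. Compound 1 therefore has no exact position: it sits at the limit of > 50000 nM in this assay, at which 3 of the 3 values shown sit.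

Compound 4 `[N-]=[N+]=Nc1c(F)c(=O)[nH]c(=O)n1[C@@H]1O[C@H](CO)[C@@H](O)[C@H]1O` has fluoro in place of hydrogen on an aromatic carbon, ortho to an azido group: fluoro in place of hydrogen on an aromatic carbon.

The measured steps, a step that the two limits leave unreadable from compound 1 to compound 2 and a step that the two limits leave unreadable from compound 1 to compound 3, replace the azido group rather than this hydrogen. Neither gives a size to carry over, and a step that the two limits leave unreadable from compound 2 to compound 3 gives none either. Any readable step in this assay can only be expected toward stronger inhibition, and it may remain hidden by the limit.

The expected change is an at least 2.5-fold lower number from compound 1 to compound 4 (0.39 log units; beyond the scatter).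

The estimate for compound 4 is 20000 nM, with an expected range of 2000 nM to 50000 nM.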

Compound 4, half-maximal inhibitory concentration: 600 nM
Estimate against measurement, compound 4: 33-fold (1.52 log units) above, and the stated range ends above it.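

In this assay, among these compounds, fluoro in place of hydrogen on an aromatic carbon, ortho to an azido group, gives the only readable step, an at least 83-fold lower number from compound 1 to compound 4 (1.92 log units; beyond the scatter). On these data alone, compound 1 gives > 50000 nM, which is a limit, so the full size of this step remains unknown. Among the compounds shown here, the steps that replace the azido group cannot be read, and only this change moves a compound off the limit: the limit of > 50000 nM in this assay, at which 3 of the 4 values shown sit.

It remains open whether the step depends on the azido group: no compound shown pairs fluoro with methylamino or hydroxyamino. Chloro or methyl on this carbon also remains untested among the compounds shown.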